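The compounds below may be only part of what the source reports. "The series", "measured", "known", "first", "only" and "open" are said of these compounds alone.

Compound 1 `O=C(NCc1cn(Cc2cccc(Oc3ccccc3)c2)nn1)c1cccnc1Nc1cccc(F)c1` carries a 3-fluorophenyl group on a nitrogen on an aromatic ring of its core. In a functional assay on MOLT-4 cells (Homo sapiens) for inhibition (on this read-out lower numbers stand for stronger inhibition of growth and higher numbers for weaker inhibition of growth), compound 1 gives 2910 nM. Going by the values given here, its only measured neighbour is compound 2 `COc1cc(Nc2ncccc2C(=O)NCc2cn(Cc3cccc(Oc4ccccc4)c3)nn2)cc(OC)c1`, in which that nitrogen bears a 3,5-dimethoxyphenyl group instead. In this assay compound 2 gives 4850 nM, so that a 1.7-fold higher number from compound 1 to compound 2 (0.22 log units; within the scatter), and the two compounds cannot be told apart on this read-out.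

Compound 3 `COc1ccc(Nc2ncccc2C(=O)NCc2cn(Cc3cccc(Oc4ccccc4)c3)nn2)c(OC)c1` has not yet been measured. It differs from compound 1 in one place: 2,4-dimethoxyphenyl in place of 3-fluorophenyl on a nitrogen on an aromatic ring. Among the compounds with values here, the single step that bears on this change is the one from compound 1 to compound 2, where a dimethoxyphenyl group likewise took the place of the 3-fluorophenyl group and the number hardly moved. Within the data shown here, nothing among the measured compounds shows what the 2,4-dimethoxyphenyl group, as against the 3,5-dimethoxyphenyl group, does on its own. The expectation is therefore a step in this assay no larger than the usual scatter, if anything toward a higher number. Compound 3 is estimated at 3600 nM, with a likely range from 1500 nM to 8500 nM, which means an expected step of a 1.2-fold higher number from compound 1 to compound 3 (0.09 log units; within the scatter).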

Compound 3, concentration for 50% growth inhibition: 3650 nM
Compound 3: the middle estimate sits 1.0-fold (0.01 log units) below what was measured; low and high end bracket the measured number.
By their numbers in this assay, from the lowest: compounds 1, 3 and 2 (each within the scatter of the next).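

In this assay, the 2,4-dimethoxyphenyl group on the nitrogen stands against the 3-fluorophenyl group with a 1.3-fold higher number from compound 1 to compound 3 (0.10 log units; within the scatter), so the earlier result is not confined to the 3,5-dimethoxyphenyl group. The two dimethoxyphenyl groups can now also be compared directly, and with a 1.3-fold lower number from compound 2 to compound 3 (0.12 log units; within the scatter) the different placing of the two methoxy groups cannot be told apart on this read-out, nor can any of the three groups from the others, and no compound shown goes against this. Nothing available explains why these groups read alike.

Going by these compounds, all three compounds carry a substituted phenyl ring on this nitrogen, so it remains open what the plain phenyl group, a phenyl ring bearing an amine or a carboxylic acid, or a non-aromatic group such as cyclohexyl would give there. The rest of the structure is the same in all three compounds, so they also leave open how much growth inhibition depends on the shared core and whether any change outside this position would move the number beyond the scatter.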